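The source may report more compounds than this note shows. Statements on the series, on what has been measured and on what is new or still open speak of the compounds shown alone.

Measured so far:
compound 1, `CC[C@@H](C)[C@H](N)CN(C(=O)[C@@H]1C[C@H]1c1ccccc1)c1ccc(-c2ccccc2)cc1`: 1.4 nM
compound 2, `Cc1cccc(-c2ccc(N(C[C@@H](N)CC(C)C)C(=O)[C@@H]3C[C@H]3c3ccccc3)cc2)c1`: 1200 nM

Of the compounds shown here, two have been measured in a functional assay for agonist activity at G protein-coupled receptor 88 (Homo sapiens), read by HTRF and cAMP accumulation; a lower number here means that less compound is needed, a higher number that more compound is needed for the effect. Compound 1 `CC[C@@H](C)[C@H](N)CN(C(=O)[C@@H]1C[C@H]1c1ccccc1)c1ccc(-c2ccccc2)cc1` gives 1.4 nM. Compound 2 `Cc1cccc(-c2ccc(N(C[C@@H](N)CC(C)C)C(=O)[C@@H]3C[C@H]3c3ccccc3)cc2)c1` gives 1200 nM, the higher of the two numbers, and its gap to compound 1 lies far beyond the usual scatter. Compound 3 `CC(C)C[C@H](N)CN(C(=O)[C@@H]1C[C@H]1c1ccccc1)c1ccc(-c2ccc(Cl)cc2)cc1` has not yet been measured. It differs from compound 2 in one place: 4-chlorophenyl in place of 3-methylphenyl on an aromatic carbon. Among the compounds with values here, no step between measured compounds isolates this change, and compound 1 and compound 2 differ in more than one place, so their two values show only that a plain phenyl variant sits far below a 3-methylphenyl variant. A step toward a lower number is expected for compound 3, because compound 2 stands at 1200 nM while compound 1 stands at 1.4 nM. The expected step is a 12-fold lower number from compound 2 to compound 3 (1.08 log units; beyond the scatter). Compound 3 is estimated at 100 nM, in a range from 10 nM to 1000 nM.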

Compound 3, half-maximal effective concentration: 640 nM
For compound 3 the middle estimate is 6.4-fold (0.81 log units) below the measured one; the measured number falls inside the stated range.
By their numbers in this assay, from the lowest: compound 1; then compounds 3 and 2 (each within the scatter of the next).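

In this assay, exchanging 3-methylphenyl for 4-chlorophenyl on this aromatic carbon gives a 1.9-fold lower number from compound 2 to compound 3 (0.27 log units; within the scatter), so the two groups cannot be told apart here. The exchange swaps a methyl for a chlorine and shifts the substituent's place on the ring in one step, and the two compounds land within the scatter of each other even with both alterations made at once. No measurement shown here offers an explanation of this result.

The compounds shown leave open what 3-chlorophenyl or 4-methylphenyl would give on this same scaffold, which would separate the effect of the atom from that of its place on the ring. They also leave open whether an amine or a carboxylic acid on this ring would give a number clearly apart from these two.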